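The source may hold more compounds than are shown below. What is called first, only, known or untested is meant among the compounds shown, and "the series" means these compounds.

Two compounds of the series have numbers in a functional assay on KYSE-410 cells (Homo sapiens) for antiproliferative activity, read by MTT assay, with a stated time of 72 h; a lower number here means a stronger inhibitor, a higher number a weaker inhibitor. Compound 1 `O=C(Nc1cc(F)cc(F)c1)c1cc(=O)[nH]c2cc(Cl)ccc12` gives 11000 nM there. Compound 2 `O=C(Nc1cccc(F)c1)c1cc(=O)[nH]c2cc(-c3cccc(F)c3)ccc12` gives 10900 nM in this assay, the lower of the two numbers, though the gap to compound 1 is within the scatter, so the two read alike. Compound 3 `C#Cc1ccc2c(C(=O)Nc3cccc(F)c3)cc(=O)[nH]c2c1` has not been measured. It differs from compound 2 by ethynyl in place of 3-fluorophenyl on an aromatic carbon. Among the measured compounds shown here, nothing among the measured pairs isolates this change; compound 1, carrying chloro at the same place, sits close to compound 2. A step within the scatter is expected, a 1.1-fold higher number from compound 2 to compound 3 (0.04 log units; within the scatter). Compound 3 is estimated at 12000 nM, within 4000 nM to 40000 nM.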

Compound 3, half-maximal inhibitory concentration: 9700 nM
Beside the measured number, compound 3's estimate is 1.2-fold (0.09 log units) above it; the measured number falls inside the stated range.
By their numbers in this assay, from the lowest: compounds 3, 2 and 1 (each within the scatter of the next).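

In this assay, among the compounds shown here, replacing 3-fluorophenyl with ethynyl on this aromatic carbon gives a 1.1-fold lower number from compound 2 to compound 3 (0.05 log units; within the scatter), and this is the first step that isolates the position. Losing the six-membered aromatic ring and introducing a triple bond therefore leaves the read-out unchanged within the scatter for this pair. No available evidence bears on why the two compounds read alike. Going by these compounds, it remains open whether an amine, a carboxylic acid or a longer alkyl chain at this position would separate from compound 2 and compound 3.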